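The source may report more compounds than this note shows. Statements on the series, on what has been measured and on what is new or still open speak of the compounds shown alone.

Compound 3 `Fc1cccc(-c2nc(Nc3ccc(Br)cc3)c3cc(F)ccc3n2)c1` stands at the limit of a functional assay on HT29-AK cells (Homo sapiens) for cytotoxicity, read by MTT assay, with a stated time of 48 h; a higher number here means a weaker inhibitor, a lower number a stronger inhibitor. In this assay compound 3 gives > 50000 nM, which is a limit and not a number. Compound 2 `Fc1cccc(Nc2nc(-c3cccc(F)c3)nc3ccc(F)cc23)c1` sits at the same limit. In this assay compound 2 gives > 50000 nM, likewise a limit. Compound 1 `COc1ccc(Nc2nc(-c3cccc(F)c3)nc3ccc(F)cc23)cc1` is the only one of the three with a number. In this assay compound 1 gives 42300 nM. The steps among them are small or unreadable: an at least 1.1-fold higher number from compound 1 to compound 2 (0.07 log units; that floor lies within the scatter); an at least 1.1-fold higher number from compound 1 to compound 3 (0.07 log units; that floor lies within the scatter); a step that the two limits leave unreadable from compound 2 to compound 3. What the series mostly shows is the limit of > 50000 nM in this assay, at which 2 of the 3 values shown sit.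

Compound 4 `Oc1cccc(Nc2nc(-c3cccc(F)c3)nc3ccc(F)cc23)c1` differs from compound 3 in one place: 3-hydroxyphenyl in place of 4-bromophenyl on a nitrogen on an aromatic ring. The measured steps that bear on this exchange of the group on the nitrogen are an at least 1.1-fold higher number from compound 1 to compound 2 (0.07 log units; that floor lies within the scatter) and a step that the two limits leave unreadable from compound 2 to compound 3, neither of which gives a readable size or reaches beyond the scatter. The step that the limit leaves unreadable from compound 3 to compound 4 is therefore expected to stay within the scatter. The estimate for compound 4 is 60000 nM, expected between 20000 nM and 200000 nM, with a fair chance that this assay again reports only a limit.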

Compound 4, half-maximal inhibitory concentration: > 50000 nM
Compound 4 was reported as a limit; the forecaster's own chance of this, stated with the estimate: 60%; the middle value does not contradict the limit.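

Compound 4 gives > 50000 nM in this assay, which is again a limit and not a number, so a group with a hydrogen-bond donor and acceptor on this phenyl ring, unlike the 4-bromophenyl it replaces, yields no readable gain. Among the compounds shown here, the only step that can be read is an at least 1.1-fold higher number from compound 1 to compound 4 (0.07 log units; that floor lies within the scatter), and the steps from compound 2 and from compound 3 to compound 4 cannot be read. Hydroxy now joins fluoro and bromo among the groups on this ring that give no number, and the series is increasingly defined by: the limit of > 50000 nM in this assay, at which 3 of the 4 values shown sit.

What the compounds shown leave open is whether a phenyl ring carrying an amine or a carboxylic acid, or a longer chain on the nitrogen in place of the ring, would give a number in this assay. As far as these compounds go, the sizes of the steps among compound 2, compound 3 and compound 4 also stay open.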